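The compounds below may be only part of what the source reports. "The series", "measured", "known", "first", "only" and "open" are said of these compounds alone.

Working notes on the series. In a functional assay (aorta) with Oryctolagus cuniculus as the target (a higher number here means weaker binding, a lower number tighter binding), compound 1 (`COc1cc(C(C)=O)ccc1OCCCN1CCC(C(c2ccc(F)cc2)c2ccc(F)cc2)CC1`) gives 1.59 nM and compound 2 (`COc1cc(C(C)=O)ccc1OCCCN1CCC(C(c2ccc(F)cc2)c2ccc(F)c(F)c2)CC1`) gives 1.26 nM. Among the compounds with values here, these are the only two numbers available, and they lie within the scatter of each other, so compound 1 has no distinct rank.

Compound 3 (`COc1cc(C(C)=O)ccc1OCCCN1CCC(C(C(N)=O)(c2ccc(F)cc2)c2ccc(F)cc2)CC1`) keeps the core of compound 1 and differs from it by one change: carbamoyl in place of hydrogen on a saturated chain carbon bound to two aromatic carbons and a saturated ring carbon. In words, this is carbamoyl in place of hydrogen on a saturated chain carbon bound to two aromatic carbons and a saturated ring carbon.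

Within the data shown here, the one measured step, a 1.3-fold lower number from compound 1 to compound 2 (0.10 log units; within the scatter), is fluoro in place of hydrogen on an aromatic carbon. It involves a different group at a different place and offers only weak guidance here. Among the measured compounds shown here, no measured step touches the saturated chain carbon, so size and direction remain a judgement with a wide margin. A moderate move to a higher number in this assay, beyond the scatter, is expected.

The expected change is a 3.1-fold higher number from compound 1 to compound 3 (0.50 log units; beyond the scatter). For compound 3 the estimate is 5 nM, with an expected range of 1 nM to 25 nM.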

Compound 3, dissociation constant: 25.1 nM
Beside the measured number, compound 3's estimate is 5.0-fold (0.70 log units) below it; measured number outside the range, above it.
By their numbers in this assay, from the lowest: compounds 2 and 1 (each within the scatter of the next); then compound 3.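

In this assay, the saturated chain carbon bound to two aromatic carbons and a saturated ring carbon proves sensitive to substitution: carbamoyl in place of hydrogen there gives a 16-fold higher number from compound 1 to compound 3 (1.20 log units; beyond the scatter), a large step towards weaker binding. Within the data shown here, the only earlier step, a 1.3-fold lower number from compound 1 to compound 2 (0.10 log units; within the scatter), is a change on an aromatic carbon and stays within the scatter, so compound 3 gives the first clear separation and the first reading at this carbon. Nothing available here accounts for the size or direction of this step.

The compounds shown leave open whether the step belongs to carbamoyl itself or would follow any replacement of that hydrogen; a hydroxyl, a methyl, a nitrile or a carboxylic acid on the same carbon would separate these possibilities. Also open, on these data alone, is whether the added fluoro of compound 2 would leave the number unchanged in the presence of carbamoyl, or whether an N-methyl carbamoyl at this carbon would give a step of similar size.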